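This account rests on a few compounds, and the source may have more. Where it says the series, first, only, none or still open, it means among the compounds named here.

Measured compounds: compound 1 `CC(C)(C)c1ccc(C(=O)N2CCC3(CC2)C(=O)N(CC(=O)N2CCN(S(C)(=O)=O)CC2)CN3c2ccccc2)cc1` gives 19000 nM in an assay on HEK293 cells for displacement of a labelled ligand from NPC1-like intracellular cholesterol transporter 1 (Homo sapiens); on this read-out lower numbers stand for stronger inhibition and higher numbers for weaker inhibition; compound 2 `CC(C)(C)c1ccc(C(=O)N2CCC3(CC2)C(=O)N(CC(=O)NCCN)CN3c2ccccc2)cc1` gives 7000 nM; compound 3 `CC(C)(C)c1ccc(C(=O)N2CCC3(CC2)C(=O)N(CC(=O)N2CCCCC2CO)CN3c2ccccc2)cc1` gives 11800 nM.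

Compound 3 stands second highest of the three numbers, though its steps to both neighbours, a 1.6-fold lower number from compound 1 to compound 3 (0.21 log units; within the scatter) and a 1.7-fold higher number from compound 2 to compound 3 (0.23 log units; within the scatter), stay within the scatter. Compound 4 `CC(C)(C)c1ccc(C(=O)N2CCC3(CC2)C(=O)N(CC(=O)N2CCNCC2)CN3c2ccccc2)cc1` differs from compound 3 by piperazin-1-yl in place of 2-(hydroxymethyl)piperidin-1-yl on a carbonyl carbon. For the measured compounds named here, the steps that bear on this are the three earlier exchanges on the same carbonyl carbon: a 2.7-fold lower number from compound 1 to compound 2 (0.43 log units; beyond the scatter) was modest and beyond the scatter, while a 1.6-fold lower number from compound 1 to compound 3 (0.21 log units; within the scatter) and a 1.7-fold higher number from compound 2 to compound 3 (0.23 log units; within the scatter) were not. All such exchanges have moved the numbers little, so compound 4 is expected to differ from compound 3 by a step within the scatter, a 1.3-fold lower number from compound 3 to compound 4 (0.12 log units; within the scatter). Compound 4 is estimated at 9000 nM, within 4000 nM to 20000 nM.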

Compound 4, half-maximal inhibitory concentration: 22000 nM
The estimate for compound 4 lay 2.4-fold (0.39 log units) below the measured number, outside the stated range (above it).
By their numbers in this assay, from the lowest: compounds 2, 3, 1 and 4 (each within the scatter of the next, the first and the last beyond it).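

In this assay, a 1.9-fold higher number from compound 3 to compound 4 (0.27 log units; within the scatter) and a 1.2-fold higher number from compound 1 to compound 4 (0.06 log units; within the scatter) both stay within the scatter, so neither piperazin-1-yl for 2-(hydroxymethyl)piperidin-1-yl nor hydrogen for methylsulfonyl on the ring amine nitrogen separates these ring amides. Piperazin-1-yl for (2-aminoethyl)amino gives a 3.1-fold higher number from compound 2 to compound 4 (0.50 log units; beyond the scatter) and is modest but beyond the scatter, which sets the open chain of compound 2 apart from two ring amides, though compound 3 goes against this. No measurement here accounts for these steps. The compounds shown leave open whether a longer chain ending in an amine, or a carboxylic acid, on this carbonyl carbon would move the number outside the range of these four.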